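Compound 4: amino group removed from the carbonyl side chain

The compounds below may be only part of what the source reports. "The series", "measured", "known", "first", "only" and "open" are said of these compounds alone.

Compound 1 `COc1cc(Cl)cc(-c2nn(-c3cccc(NC(=O)Nc4ccc(Cl)c(C(F)(F)F)c4)c3)cc2-c2ccncc2)c1` gives -16% in a functional assay on IGROV-1 cells (Homo sapiens) for inhibition, read by sulforhodamine B assay, with a stated time of 48 h, tested at 100 uM; on this read-out lower numbers stand for a stronger effect and higher numbers for a weaker effect at the one concentration tested. Compound 2 `COc1cc(Cl)cc(-c2nn(-c3cccc(NC(=O)Nc4ccc(Cl)c(Cl)c4)c3)cc2-c2ccncc2)c1` gives 8% in this assay, and compound 3 `COc1cc(Cl)cc(-c2nn(-c3cccc(NC(=O)Nc4cccc(C(F)(F)F)c4)c3)cc2-c2ccncc2)c1` gives -12%. Compound 3 thus stands second highest of the three numbers, with a number 4 percentage points higher from compound 1 to compound 3 (within the scatter) and a number 20 percentage points lower from compound 2 to compound 3 (beyond the scatter); the remaining step is a number 24 percentage points higher from compound 1 to compound 2 (beyond the scatter). Compound 4 `COc1cc(Cl)cc(-c2nn(-c3cccc(NC(=O)c4cccc(C(F)(F)F)c4)c3)cc2-c2ccncc2)c1` differs from compound 3 by 3-(trifluoromethyl)phenyl in place of (3-(trifluoromethyl)phenyl)amino on a carbonyl carbon. Among the compounds with values here, none of the measured steps touches this part of the molecule: each of them changes only the aryl on the amide-type nitrogen or its substituents, and the largest is modest. No shift beyond the scatter is therefore expected in this assay. The estimate for compound 4 is -10%, within -35% to 15%. The expected step is a number 2 percentage points higher from compound 3 to compound 4 (within the scatter).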

Compound 4, a percentage reported as activity, at one concentration (the size of the read-out at that concentration, not a potency): 70%
Compound 4: the middle estimate sits 80 percentage points below what was measured, outside the stated range (above it).
By their numbers in this assay, from the lowest: compounds 1 and 3 (each within the scatter of the next); then compound 2; then compound 4.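

Working notes: in this assay the amino group on the carbonyl carbon is far more sensitive than the aryl substituents. Removing it gives a number 82 percentage points higher from compound 3 to compound 4 (beyond the scatter) and the other two pairs agree, with a number 62 percentage points higher from compound 2 to compound 4 (beyond the scatter) and a number 86 percentage points higher from compound 1 to compound 4 (beyond the scatter) all large, while the earlier aryl changes were modest at most. No measurement at hand bears on the reason for this shift.

Still open, as far as these compounds go, is whether the amino nitrogen itself carries the difference, which a methylene group or an oxygen in its place on the carbonyl carbon would test.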